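A few compounds are considered here, and "the series" means these few. Any claim that something is new, unique, unknown or untested is made for them only; others in the source may bear on it.

Compound 1 `CCOC1=C(C(=O)c2ccccc2)C(c2ccc(Br)cc2)N(CCCn2ccnc2)C1=O` and compound 2 `O=C(C1=C(Nc2ccc(Cl)cc2)C(=O)N(CCCn2ccnc2)C1c1ccc(Br)cc1)c1ccccc1` share one core and differ at a single double-bonded ring carbon. In a functional assay on U2OS cells (Homo sapiens) for antiproliferative activity, read by MTT assay, with a stated time of 72 h (a higher number here means a weaker inhibitor, a lower number a stronger inhibitor), compound 1 gives 21900 nM and compound 2 gives 22800 nM; the step of a 1.0-fold higher number from compound 1 to compound 2 (0.02 log units; within the scatter). Compound 2 thus holds the higher of the two numbers, yet sits within the scatter of compound 1. Compound 3 `O=C(C1=C(Nc2cccc(Br)c2)C(=O)N(CCCn2ccnc2)C1c1ccc(Br)cc1)c1ccccc1` differs from compound 2 by 3-bromophenyl in place of 4-chlorophenyl on an amine nitrogen. Going by the values given here, no measured step touches this amine nitrogen, and the only step available was flat. The step of a 1.0-fold higher number from compound 2 to compound 3 (0.00 log units; within the scatter) is therefore expected to stay within the scatter. For compound 3 the estimate in this assay is 23000 nM, expected between 10000 nM and 50000 nM.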

Compound 3, half-maximal inhibitory concentration: 11900 nM
Beside the measured number, compound 3's estimate is 1.9-fold (0.29 log units) above it; measured number inside the range.
By their numbers in this assay, from the lowest: compounds 3, 1 and 2 (each within the scatter of the next).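

In this assay the first change read at the amine nitrogen, 3-bromophenyl in place of 4-chlorophenyl, gives a 1.9-fold lower number from compound 2 to compound 3 (0.28 log units; within the scatter) and so stays inside the scatter. Replacing ethoxy on the double-bonded ring carbon with (3-bromophenyl)amino gives a 1.8-fold lower number from compound 1 to compound 3 (0.26 log units; within the scatter) and does not separate these two compounds either. No evidence bears on this result.

Halogen identity and ring position change together in the 3-bromophenyl step, leaving 3-chlorophenyl and 4-bromophenyl as open comparisons. Also open, from the compounds shown here alone, is whether a longer alkyl chain on this nitrogen would move the number beyond the scatter.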